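A few compounds are considered here, and "the series" means these few. Any claim that something is new, unique, unknown or untested is made for them only; others in the source may bear on it.

Compound 1, `Cc1cccc(NCc2cnc3cc([N+](=O)[O-])ccc3n2)c1`, gives 77000 nM in a functional assay on PC-3 cells (Homo sapiens) for cytotoxicity, read by MTT assay, with a stated time of 96 h; a lower number here means a stronger inhibitor, a higher number a weaker inhibitor.
Compound 2, `O=[N+]([O-])c1ccc2nc(CNc3ccc(Cl)cc3)cnc2c1`, gives 70000 nM in this assay.
Compound 3, `O=C(O)c1ccc(NCc2cnc3cc([N+](=O)[O-])ccc3n2)cc1`, gives 45000 nM in this assay.

All three share one core and differ only in the group attached to the amine nitrogen. Compound 2 stands second highest of the three numbers; the step of a 1.1-fold lower number from compound 1 to compound 2 (0.04 log units; within the scatter) and the step of a 1.6-fold lower number from compound 2 to compound 3 (0.19 log units; within the scatter) both stay within the scatter of repeated measurements, so the three compounds cannot be told apart on these numbers.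

The new compound 4, `CNC(=O)c1ccc(NCc2cnc3cc([N+](=O)[O-])ccc3n2)cc1`, is made from compound 2 by the change (methylcarbamoyl in place of chloro on an aromatic carbon). Of the measured steps, the one that bears most directly on it is the exchange of chloro for carboxy on an aromatic carbon, a 1.6-fold lower number from compound 2 to compound 3 (0.19 log units; within the scatter), which was within the scatter. The step of a 1.1-fold lower number from compound 1 to compound 2 (0.04 log units; within the scatter) changed the whole aryl group and was also within the scatter. For the measured compounds named here, nothing measured so far therefore points to a move beyond the scatter in this assay in either direction. Compound 4 is expected to give about 55000 nM, in a range from 25000 nM to 120000 nM, an expected step of a 1.3-fold lower number from compound 2 to compound 4 (0.10 log units; within the scatter).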

Compound 4, half-maximal inhibitory concentration: 49000 nM
Beside the measured number, compound 4's estimate is 1.1-fold (0.05 log units) above it, within the range that was stated.
By their numbers in this assay, from the lowest: compounds 3, 4, 2 and 1 (each within the scatter of the next).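

At this position, on an aromatic carbon para to a large group, methylcarbamoyl with its 4 heavy atoms in place of the single chloro atom gives a 1.4-fold lower number from compound 2 to compound 4 (0.15 log units; within the scatter), so in this assay this larger group, with its hydrogen-bond donor and acceptor, produces no move beyond the scatter. Methylamino in place of hydroxy on the carbonyl carbon gives a 1.1-fold higher number from compound 3 to compound 4 (0.04 log units; within the scatter), so the carboxy and methylcarbamoyl groups cannot be told apart at this position. No measurement here explains why these exchanges leave the numbers so close.

As far as these compounds go, whether an amine or a longer chain on the amide nitrogen at this position would give a step beyond the scatter remains open. All four compounds also carry the nitro group on the shared core, which leaves open what a nitrile in its place would do.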